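Removing the fluorine from a weak nucleoside inhibitor

A few compounds are considered here, and "the series" means these few. Any claim that something is new, unique, unknown or untested is made for them only; others in the source may bear on it.

Compound 1 `N#C[C@]1(O)[C@H](O)[C@@H](CO)O[C@@H](n2cc(F)c(O)nc2=O)[C@@H]1O`: 4500 nM
Compound 2 `Cc1cn([C@@H]2O[C@H](CO)[C@@H](O)[C@@](O)(C#N)[C@H]2O)c(=O)nc1O`: > 500000 nM
Compound 3 `N#C[C@H]1[C@@H](O)[C@H](n2cc(F)c(O)nc2=O)O[C@H](CO)[C@H]1O`: 819000 nM

Three compounds share a sugar-like core carrying a nitrile and a pyrimidine base. In a functional assay on HeLa cells (Homo sapiens) (a lower number here means a stronger inhibitor, a higher number a weaker inhibitor), compound 1 gives 4500 nM. For compound 2 the result is a limit of the assay, > 500000 nM. Compound 3 gives 819000 nM and therefore holds the highest of the two numbers in this assay; its nearest neighbour is compound 1, whose number is lower beyond the scatter.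

Compound 4 `N#C[C@H]1[C@@H](O)[C@H](n2ccc(O)nc2=O)O[C@H](CO)[C@H]1O` differs from compound 3 by hydrogen in place of fluoro on an aromatic carbon. Among the compounds with values here, the only measured step at the same aromatic carbon is an at least 110-fold higher number from compound 1 to compound 2 (2.04 log units; beyond the scatter), which exchanged fluoro for methyl rather than for hydrogen and pushed the result to the limit (the limit of > 500000 nM in this assay, at which 1 of the 3 values shown sits). Taking that as the nearest guide, compound 4 is expected to move a 2.4-fold higher number from compound 3 to compound 4 (0.39 log units; beyond the scatter), a further weakening that may again reach the limit of this assay. The estimate for compound 4 is 2000000 nM, within a range from 400000 nM to 10000000 nM.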

Compound 4, half-maximal inhibitory concentration: 811000 nM
Estimate against measurement, compound 4: 2.5-fold (0.39 log units) above, within the range that was stated.
By their numbers in this assay, from the lowest: compound 1; then compounds 4 and 3 (each within the scatter of the next).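

In this assay, hydrogen in place of fluoro on this aromatic carbon leaves the two compounds within the scatter of each other: a 1.0-fold lower number from compound 3 to compound 4 (0.00 log units; within the scatter). On the core of compound 3, then, the fluoro group makes no measurable difference, although this core already sits at a very high number. The earlier step at the same carbon replaced fluoro with methyl on a different core and was large: an at least 110-fold higher number from compound 1 to compound 2 (2.04 log units; beyond the scatter). Nothing shown here explains why compound 3 and compound 4 read alike.

The compounds shown leave open whether hydrogen at this carbon would also make no measurable difference on the core of compound 1, which gives 4500 nM. They also leave open what an amine or a chlorine atom at this carbon would do on either core.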